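A few compounds are considered here, and "the series" means these few. Any claim that something is new, unique, unknown or untested is made for them only; others in the source may bear on it.

For the measured compounds named here, compound 2 `CCC(C)[C@H](NC(C)=O)c1cc(C(F)(F)F)ccc1N1CCN(C(=O)CCc2ccc(Cl)cc2Cl)CC1` gives the higher of the two numbers measured so far: in an assay on HEK293 cells for displacement of a labelled ligand from Melanocortin receptor 4 (Homo sapiens) (a lower number here means a stronger inhibitor, a higher number a weaker inhibitor), compound 2 gives 360 nM, while compound 1 `CCC(C)[C@H](NC[C@H](C)N)c1cc(C(F)(F)F)ccc1N1CCN(C(=O)CCc2ccc(Cl)cc2Cl)CC1` gives 89 nM. Going by the values given here, the only step seen, a 4.0-fold higher number from compound 1 to compound 2 (0.61 log units; beyond the scatter), accompanied acetyl in place of 2-aminopropyl on an amine nitrogen. Compound 3 `CC(C)C[C@H](NC(=O)CCN)c1cc(C(F)(F)F)ccc1N1CCN(C(=O)CCc2ccc(Cl)cc2Cl)CC1` carries 1-(((2-aminoethyl)carbonyl)amino)-3-methylbutyl in place of 1-acetamido-2-methylbutyl on an aromatic carbon. Since the entering group restores an amine, as in compound 1, a partial return toward the number of compound 1 is expected, smaller than the step seen, so a 2.4-fold lower number from compound 2 to compound 3 (0.38 log units; beyond the scatter) is the expected move. Compound 3 is therefore estimated at 150 nM, within 50 nM to 450 nM.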

Compound 3, inhibition constant: 25 nM
The estimate for compound 3 lay 6.0-fold (0.78 log units) above the measured number; measured number outside the range, below it.
By their numbers in this assay, from the lowest: compound 3; then compound 1; then compound 2.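

In this assay the change gives a 14-fold lower number from compound 2 to compound 3 (1.16 log units; beyond the scatter) while keeping the carbonyl on this nitrogen, so an amide here does not by itself give a weak number. The amide with a terminal amine also outdoes the amine-linked chain, with a 3.6-fold lower number from compound 1 to compound 3 (0.55 log units; beyond the scatter) on the same shared core. No measurement at hand explains either step. The methyl branch moves along with the amine, so the two changes cannot be separated: 1-acetamido-3-methylbutyl would isolate the branch, while a longer 4-aminobutanoyl chain would test the amine's distance.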